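Three variations on the side chain; half-life in microsomes

The compounds below may be only part of what the source reports. "The series", "measured", "known", "first", "only" and "open" are said of these compounds alone.

Going by the values given here, compound 3 `COc1ccc2[nH]c(C(=O)N3CC(=O)N(Cc4ccccc4)[C@@H](COc4ccc(F)cc4)C3)cc2c1` gives the highest of the three numbers so far in an ADME assay on microsomes from liver (Homo sapiens) for metabolic stability, with a stated time of 30 min, tested at 1 uM (a lower number here means that the compound disappears faster, a higher number that the compound lasts longer), at 0.317 h. Compound 1 `COc1ccc2[nH]c(C(=O)N3CC(=O)N(Cc4ccccc4)[C@@H](CN4CCC(C)CC4)C3)cc2c1` gives 0.267 h in this assay, and the two stand within the scatter of each other (a 1.2-fold higher number from compound 1 to compound 3 (0.07 log units; within the scatter)). Compound 2 `COc1ccc2[nH]c(C(=O)N3CC(=O)N(Cc4ccccc4)[C@@H](N4[C@H](C)CCC[C@@H]4C)C3)cc2c1` gives 0.112 h, and the step of a 2.8-fold higher number from compound 2 to compound 3 (0.45 log units; beyond the scatter) is modest but beyond the scatter; the step of a 2.4-fold lower number from compound 1 to compound 2 (0.38 log units; beyond the scatter) points the same way.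

Compound 4 `COc1ccc2[nH]c(C(=O)N3CC(=O)N(Cc4ccccc4)[C@@H](CN4CCCc5ccccc54)C3)cc2c1` is the next variation: 1,2,3,4-tetrahydroquinolin-1-yl in place of 4-fluorophenoxy on a saturated chain carbon bound to a saturated ring carbon. Among the compounds with values here, the one measured step at the same position, a 1.2-fold higher number from compound 1 to compound 3 (0.07 log units; within the scatter), shows that swapping an aromatic ether for a saturated amine there leaves the half-life within the scatter. Within the data shown here, the only step beyond the scatter, a 2.8-fold higher number from compound 2 to compound 3 (0.45 log units; beyond the scatter), concerns a group placed directly on the ring carbon, so it bears on this change only loosely. With a ring amine re-entering on the chain carbon and the aromatic ring kept, the expectation is a number close to compound 3, with any step either within the scatter or modestly lower; the expected step is a 1.3-fold lower number from compound 3 to compound 4 (0.10 log units; within the scatter). Compound 4 is expected to give 0.25 h, with a range from 0.12 h to 0.5 h.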

Compound 4, half-life: 0.183 h
Compound 4: middle estimate off by 1.4-fold (0.14 log units), on the high side; the range from low to high includes it.
By their numbers in this assay, from the lowest: compounds 2, 4, 1 and 3 (each within the scatter of the next, the first and the last beyond it).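

On the saturated chain carbon bound to a saturated ring carbon, 1,2,3,4-tetrahydroquinolin-1-yl in place of 4-fluorophenoxy gives a 1.7-fold lower number from compound 3 to compound 4 (0.24 log units; within the scatter), and in place of 4-methylpiperidin-1-yl it gives a 1.5-fold lower number from compound 1 to compound 4 (0.16 log units; within the scatter), so in this assay this position has now taken three different groups with all steps among them inside the scatter. Compound 2 stood apart from both compound 1 and compound 3 by steps beyond the scatter, but (1,2,3,4-tetrahydroquinolin-1-yl)methyl in place of 2,6-dimethylpiperidin-1-yl on a saturated ring carbon gives only a 1.6-fold higher number from compound 2 to compound 4 (0.21 log units; within the scatter), so compound 4 does not share that separation. No independent measurement accompanies these half-lives to explain them.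

Still open, on these data alone, is whether a 2.4-fold lower number from compound 1 to compound 2 (0.38 log units; beyond the scatter) reflects the group attached directly to the ring carbon or the two methyl groups on the piperidine, since the two compounds differ in both respects; (2,6-dimethylpiperidin-1-yl)methyl would separate the two. Also open, as far as these compounds go, is whether a morpholin-4-yl or a carboxylic acid on the saturated chain carbon would give a step beyond the scatter from compound 3, which no group at this position has yet done.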